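Cyclic amine swap at the thiocarbonyl of compound 1

This account rests on a few compounds, and the source may have more. Where it says the series, first, only, none or still open, it means among the compounds named here.

Measured compounds:
compound 1 `CCN(Cc1ccncc1)C(=S)SCc1ccc(C(=O)Nc2ccccc2N)cc1` — 85.2%
compound 2 `Nc1ccccc1NC(=O)c1ccc(CSC(=S)N2CCN(c3ccc(F)cc3)CC2)cc1` — 48.7%
compound 3 `Nc1ccccc1NC(=O)c1ccc(CSC(=S)N2CCN(c3ncccn3)CC2)cc1` — 64.8%

In a functional assay on MGC-803 cells (Homo sapiens) for antiproliferative activity, read by CCK-8 assay, with a stated time of 72 h, tested at 8 uM (on this read-out lower numbers stand for a weaker effect and higher numbers for a stronger effect at the one concentration tested), compound 1 gives the highest of the three numbers, standing beyond the scatter above both compound 3 and compound 2. Compound 4 `Nc1ccccc1NC(=O)c1ccc(CSC(=S)N2CCc3ccccc32)cc1` differs from compound 1 by 2,3-dihydro-1H-indol-1-yl in place of ethyl((pyridin-4-yl)methyl)amino on a thiocarbonyl carbon. For the measured compounds named here, no measured step alters this part of the shared core; the only step, a number 16.1 percentage points higher from compound 2 to compound 3 (beyond the scatter), concerns a substituent on a ring amine and does not bear directly on the change. Compounds 2 and 3 show that other ring-closed amines at the thiocarbonyl carbon sit below compound 1, so a downward step from compound 1 to compound 4 is expected, a number 20.2 percentage points lower from compound 1 to compound 4 (beyond the scatter). Compound 4 is therefore estimated at 65%, within 45% to 85%.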

Compound 4, a percentage reported as inhibition, at one concentration (the size of the read-out at that concentration, not a potency): 87%
Compound 4: the middle estimate sits 22 percentage points below what was measured, and the stated range ends below it.
By their numbers in this assay, from the lowest: compound 2; then compound 3; then compounds 1 and 4 (each within the scatter of the next).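

In this assay the change on the thiocarbonyl carbon gives a number 1.8 percentage points higher from compound 1 to compound 4 (within the scatter), so the pyridine ring and its hydrogen-bond acceptor are not needed to hold this level. It also shows that a ring-closed amine at this position can match the open ethyl((pyridin-4-yl)methyl)amino group, which compound 2 at 48.7% and compound 3 at 64.8% did not show. No measurement here explains this result. From the compounds shown here alone, whether a pyrrolidine or a morpholine would hold this level remains open, as does the effect of a methoxy group on the benzene ring of the 2,3-dihydro-1H-indol-1-yl group. Going by these compounds, with a single concentration, any difference in potency between compound 1 and compound 4 also remains open.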